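Removing the 3-methylbut-2-en-1-yl group from compound 3

The compounds below may be only part of what the source reports. "The series", "measured", "known", "first", "only" and "open" are said of these compounds alone.

Measured in an ADME assay on MCF7-DOX cells (Homo sapiens) for cytotoxicity, read by MTT assay, with a stated time of 48 h; a higher number here means a weaker inhibitor, a lower number a stronger inhibitor:
Compound 1 `COc1cc(O)c(C(=O)/C=C/c2ccc(N3CCNCC3)cc2)c(OC)c1`: 67500 nM
Compound 2 `COc1cc(O)c(C(=O)/C=C/c2cccc(N3CCN(C)CC3)c2)c(OC)c1`: 62200 nM
Compound 3 `COc1cc(OC)c(C(=O)/C=C/c2ccc(N3CCN(C(=O)OC(C)(C)C)CC3)cc2)c(O)c1CC=C(C)C`: > 100000 nM (a limit)

Compound 3 gives no number, only the limit > 100000 nM. Compound 4 `COc1cc(O)c(C(=O)/C=C/c2ccc(N3CCN(C(=O)OC(C)(C)C)CC3)cc2)c(OC)c1` differs from it in one place: hydrogen in place of 3-methylbut-2-en-1-yl on an aromatic carbon. Hydrogen replaces 3-methylbut-2-en-1-yl on an aromatic carbon. Neither compound 1 nor compound 2 carries that group. Compound 1 gives 67500 nM and compound 2 gives 62200 nM, and these two values lie within the usual scatter of each other. On that basis, a modest shift toward stronger inhibition is expected in this assay. The expected change is an at least 1.5-fold lower number from compound 3 to compound 4 (0.18 log units; that floor lies within the scatter), although a second limit remains possible. For compound 4 the estimated value is 65000 nM, with an expected range from 30000 nM to 100000 nM.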

Compound 4, half-maximal inhibitory concentration: 47300 nM
Estimate against measurement, compound 4: 1.4-fold (0.14 log units) above; measured number inside the range.
By their numbers in this assay, from the lowest: compounds 4, 2 and 1 (each within the scatter of the next). At a limit, above all of these: compound 3.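

In this assay, for the compounds shown here, removing the 3-methylbut-2-en-1-yl group from the aromatic carbon ortho to a hydroxy group gives an at least 2.1-fold lower number from compound 3 to compound 4 (0.32 log units; beyond the scatter), the first reading of a change at this position. This step is only a floor, as the value for compound 3 is a limit: the limit of > 100000 nM in this assay, at which 1 of the 4 values shown sits. With tert-butoxycarbonyl in place of hydrogen on the amine nitrogen in a ring, the step is a 1.4-fold lower number from compound 1 to compound 4 (0.15 log units; within the scatter), so the two compounds are not told apart.

The compounds shown leave open how a methyl group or an amine at this aromatic carbon would compare with hydrogen. From the compounds shown here alone, whether losing the 3-methylbut-2-en-1-yl group gives a similar step when the amine nitrogen carries hydrogen also stays open.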